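Chloro for Bromo on a Shared Quinazolinone Scaffold

This account rests on a few compounds, and the source may have more. Where it says the series, first, only, none or still open, it means among the compounds named here.

Measured so far:
compound 1, `CC1(c2ccc(NC(c3ccc(Br)cc3)c3nnnn3C(C)(C)C)cc2)NC(=O)c2ccccc2N1`, 400000 nM in an ADME assay on J774.A1 cells (Mus musculus) for cytotoxicity, read by MTT assay, with a stated time of 72 h; a higher number here means that more compound is tolerated, a lower number that less compound is tolerated
compound 2, `COc1cc(C(Nc2ccc(C3(C)NC(=O)c4ccccc4N3)cc2)c2nnnn2C(C)(C)C)cc(OC)c1OC`, "not determined" (no result reported) in this assay

Compound 2 stands nowhere on the numbers: it carries no result in this assay and so offers no anchor of its own. Compound 3, `CC1(c2ccc(NC(c3ccc(Cl)cc3)c3nnnn3C(C)(C)C)cc2)NC(=O)c2ccccc2N1`, arises from compound 2 by 4-chlorophenyl in place of 3,4,5-trimethoxyphenyl on a saturated chain carbon bound to an aromatic carbon and a nitrogen on an aromatic ring. Among the compounds with values here, with no measured step to lean on, the size and direction of this change cannot be read from compound 2; nothing beyond the usual scatter is expected. Compound 3 is estimated at 400000 nM, within 150000 nM to 800000 nM. This expectation rests on compound 1, which gives 400000 nM in this assay.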

Compound 3, half-maximal cytotoxic concentration: > 400000 nM
Compound 3 gave a limit, no number; the forecaster's own chance of this, stated with the estimate: 20%; the middle value lies on the limit itself.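

Chloro in place of bromo on an aromatic carbon gives a number no lower from compound 1 to compound 3 (the limit leaves the size open), the first step that can be followed at this position. For compound 3, > 400000 nM in this assay is a limit of the assay and not a number. The change therefore shows no loss of tolerated compound, but its size stays hidden: the limit of > 400000 nM in this assay, at which 1 of the 3 values shown sits.

The compounds shown leave open what number compound 3 would give. They also leave open how an amine or a carboxylic acid in place of the halogen would read in this assay.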